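Chalcone-pyrazole series: adding a third methoxy group

The source may hold more compounds than are shown below. What is called first, only, known or untested is meant among the compounds shown, and "the series" means these compounds.

Measured so far in a functional assay on CAKI-1 cells (Homo sapiens) for cytotoxicity, read by sulforhodamine B assay, with a stated time of 48 h, tested at 1 uM; a higher number here means a weaker effect of the compound at the concentration tested, a lower number a stronger effect:
compound 1 `COc1ccc(C(=O)/C=C/c2cc(-c3cc(OC)c(OC)c(OC)c3)n[nH]2)cc1OC` gives 94%;
compound 2 `COc1ccc(C(=O)/C=C/c2cc(-c3cc(OC)c(OC)c(OC)c3)n[nH]2)cc1` gives 89%;
compound 3 `COc1cc(-c2cc(/C=C/C(=O)c3ccc(F)c(F)c3)[nH]n2)cc(OC)c1OC` gives 84%.

Compound 1 holds the highest number of the three, but every step from it stays within the scatter: a number 5 percentage points lower from compound 1 to compound 2 (within the scatter) and a number 10 percentage points lower from compound 1 to compound 3 (within the scatter). The same holds for a number 5 percentage points lower from compound 2 to compound 3 (within the scatter). Nothing here separates the compounds.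

Compound 4 `COc1cc(C(=O)/C=C/c2cc(-c3cc(OC)c(OC)c(OC)c3)n[nH]2)cc(OC)c1OC` differs from compound 1 by methoxy in place of hydrogen on an aromatic carbon. Among the measured compounds shown here, the only measured step touching a methoxy group on that ring is a number 5 percentage points lower from compound 1 to compound 2 (within the scatter), and it did not move the number beyond the scatter. For the measured compounds named here, no step in the other direction is measured. The expected step in this assay is therefore none beyond the scatter, a number 1 percentage points lower from compound 1 to compound 4 (within the scatter).

Compound 4 is estimated at 93%, range 82% to 100%.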

Compound 4, a percentage reported as activity, at one concentration (the size of the read-out at that concentration, not a potency): 82%
Beside the measured number, compound 4's estimate is 11 percentage points above it, and the stated range covers the measured number.
By their numbers in this assay, from the lowest: compounds 4, 3, 2 and 1 (each within the scatter of the next, the first and the last beyond it).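

In this assay, among the compounds shown here, methoxy in place of hydrogen on an aromatic carbon, ortho to a methoxy group and meta to a large group, gives the first step beyond the scatter: a number 12 percentage points lower from compound 1 to compound 4 (beyond the scatter). For the compounds shown here, the earlier steps on this ring all stayed within the scatter, so this change is the first to separate two compounds, though only modestly. Nothing available explains the step.

Going by these compounds, whether an amine, a hydroxy group or a longer chain such as ethoxy at this position would move the number further remains open. A single step here supports no trend.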